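Thioether in place of aryl ether on the shared core

The source may report more compounds than this note shows. Statements on the series, on what has been measured and on what is new or still open speak of the compounds shown alone.

Compound 1 `Nc1cc(N)c2nc(-c3ccccc3)c(Oc3ccc(Cl)c(Cl)c3)nc2c1` is the reference point for this step. In a functional assay on UO-31 cells (Homo sapiens) for inhibition, read by sulforhodamine B assay, with a stated time of 48 h (on this read-out lower numbers stand for higher toxicity in this test and higher numbers for lower toxicity in this test), compound 1 gives < 100000 nM, which is a limit of the assay and not a number. Compound 2 `CCOC(=O)[C@H](CCC(=O)O)NC(=O)c1ccc(Sc2nc3cc(N)cc(N)c3nc2-c2ccccc2)cc1` carries a different substituent at the same place, and in this assay compound 2 gives < 100000 nM, again a limit. Compound 3 `COc1cc(CNc2nc3cc(N)cc(N)c3nc2-c2ccccc2)cc(OC)c1OC` in this assay gives < 50200 nM, also a limit. Compound 1 thus stands at the common limit rather than at a measured point: the limit of < 100000 nM in this assay, at which 2 of the 3 values shown sit, while (the limit of < 50200 nM in this assay, at which 1 of the 3 values shown sits). Among the compounds with values here, no pair of measured compounds differs in only one place, and no measured step exists to calibrate the change.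

Compound 4 `COc1ccc(Sc2nc3cc(N)cc(N)c3nc2-c2ccccc2)cc1` is the compound still to be measured. It differs from compound 1 by (4-methoxyphenyl)sulfanyl in place of 3,4-dichlorophenoxy on an aromatic carbon. Every value in the set is a limit. The size of the change cannot be read from measured steps, and the expected movement from compound 1 to compound 4 in this assay is estimated as a step that the limit leaves unreadable from compound 1 to compound 4, none beyond the scatter relative to the limit at which compound 1 sits. Compound 4 is expected to give about 50000 nM in this assay, with a range from 10000 nM to 100000 nM, and another limit rather than a number remains likely.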

Compound 4, concentration lethal to 50% of the cells: < 100000 nM
Compound 4 was reported as a limit; the forecaster's own chance of this, stated with the estimate: 60%; the middle value is on the limit's open side.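

In this assay, within the data shown here, compound 4 gives < 100000 nM, a limit of the assay and not a number, so no step from compound 1 to compound 4 can be read. The compounds shown leave open how large any change at this place on the shared core would be, as every value shown remains a limit.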